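Ester variation on a nitrophenyl cyclohexanecarboxamide scaffold

The source may report more compounds than this note shows. Statements on the series, on what has been measured and on what is new or still open speak of the compounds shown alone.

Of the compounds shown here, two have been measured in a functional assay on HepG2 cells (Homo sapiens) for inhibition, read by MTT assay, with a stated time of 72 h; on this read-out higher numbers stand for weaker inhibition and lower numbers for stronger inhibition. Compound 1 `Cc1ccc(C(=O)OC2(C(=O)Nc3ccc([N+](=O)[O-])cc3)CCCCC2)cc1` gives 61.2 nM. For the measured compounds named here, compound 2 `O=C(OC1(C(=O)Nc2ccc([N+](=O)[O-])cc2)CCCCC1)C(O)c1ccccc1` gives 7.7 nM, the lowest of the two numbers, with compound 1 as its only neighbour. Going by the values given here, the single measured step, a 7.9-fold lower number from compound 1 to compound 2 (0.90 log units; beyond the scatter), came from putting hydroxy(phenyl)methyl in place of 4-methylphenyl on the carbonyl carbon of the ester.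

Compound 3 `CC(=O)Oc1ccccc1C(=O)OC1(C(=O)Nc2ccc([N+](=O)[O-])cc2)CCCCC1` is not yet measured. It differs from compound 2 by 2-acetoxyphenyl in place of hydroxy(phenyl)methyl on a carbonyl carbon. With 2-acetoxyphenyl, compound 3 again carries an aromatic ring directly on the ester carbonyl, as compound 1 does, and it loses the hydrogen-bond donor that set compound 2 apart. Among the compounds with values here, the only step available for guidance is the one from compound 1 to compound 2, and compound 3 undoes part of what that step introduced. Within the data shown here, the number for compound 3 in this assay is therefore expected to rise back toward that of compound 1, by a 4.5-fold higher number from compound 2 to compound 3 (0.66 log units; beyond the scatter), although the acetoxy substituent has no precedent among the measured compounds. The estimate for compound 3 is 35 nM, with a range from 9 nM to 140 nM.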

Compound 3, half-maximal inhibitory concentration: 17.7 nM
Compound 3: middle estimate off by 2.0-fold (0.30 log units), on the high side, and the stated range covers the measured number.
By their numbers in this assay, from the lowest: compound 2; then compound 3; then compound 1.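

With three compounds in this assay, the change from hydroxy(phenyl)methyl, which carries a hydrogen-bond donor, to 2-acetoxyphenyl, which carries none, gives a 2.3-fold higher number from compound 2 to compound 3 (0.36 log units; beyond the scatter), and compound 2 now has the lowest number of the three, with its steps to both others beyond the scatter. The comparison of the two groups that place an aromatic ring directly on the ester carbonyl gives a 3.5-fold lower number from compound 1 to compound 3 (0.54 log units; beyond the scatter), so at this position such a ring does not fix the number, and what the ring carries goes with a difference beyond the scatter. Nothing shown here explains either step.

The three compounds leave open whether the hydroxy group of hydroxy(phenyl)methyl goes with the low number of compound 2 or whether the carbon between ring and carbonyl is enough, a question that a benzyl group on the same carbonyl carbon would address. They also cannot separate the acetoxy group of compound 3 from the mere presence of a different ring substituent, and a 2-hydroxyphenyl or 2-methoxyphenyl group in its place would bear directly on that.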